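Removing the amino group: from compound 2 to compound 4

The source may report more compounds than this note shows. Statements on the series, on what has been measured and on what is new or still open speak of the compounds shown alone.

Measured so far:
compound 1 `ClCc1cccc(Cn2cnc3c(Cl)nc(Cl)nc32)c1`: 2690 nM
compound 2 `Nc1nc(Cl)c2ncn(Cc3ccccc3CCl)c2n1`: 17800 nM
compound 3 `ClCc1ccc(Cn2cnc3c(Cl)nc(Cl)nc32)cc1`: 1950 nM

All three compounds were tested in a functional assay on CCRF-CEM cells (Homo sapiens) for cytotoxicity, read by sulforhodamine B assay, with a stated time of 48 h; a lower number here means a stronger inhibitor of growth, a higher number a weaker inhibitor of growth. Among them, compound 2 gives the highest number, 17800 nM, so it is the weakest inhibitor of growth in this set. Compound 1, with 2690 nM, and compound 3, with 1950 nM, both lie well below it, and each of those gaps is beyond the usual scatter of this kind of measurement. Compound 1 and compound 3 are within the scatter of each other, so nothing can be said about their order.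

The step considered here leads from compound 2 to compound 4 `ClCc1ccccc1Cn1cnc2c(Cl)ncnc21`, a compound not yet measured. The change is: hydrogen in place of amino on an aromatic carbon. Only the amino group leaves; everything else in compound 2 stays as it is.

Within the data shown here, no measured pair in this set differs in exactly this way, so there is no directly comparable step to lean on. Compound 2 carries the amino group and sits highest; compound 1 and compound 3 lack it and sit lower, though they differ from compound 4 in other places as well. On that basis, compound 4 is expected to give a lower number than compound 2, with a step of about a 3.6-fold lower number from compound 2 to compound 4 (0.55 log units; beyond the scatter), though a step no larger than the scatter cannot be ruled out. Compound 4 is estimated at 5000 nM, in the range 1500 nM to 16000 nM.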

Compound 4, concentration for 50% growth inhibition: 1280 nM
The estimate for compound 4 lay 3.9-fold (0.59 log units) above the measured number, and the stated range ends above it.
By their numbers in this assay, from the lowest: compounds 4, 3 and 1 (each within the scatter of the next, the first and the last beyond it); then compound 2.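

Among these compounds, this is the first pair here that differs in one place only, so a change in this assay can now be tied to a single group. Replacing the amino group with hydrogen on the aromatic carbon between two ring nitrogen atoms gives a 14-fold lower number from compound 2 to compound 4 (1.14 log units; beyond the scatter), a large step, and in this pair the compound without the amino group is clearly the stronger inhibitor of growth. Nothing at hand explains why this single change has so large an effect.

From the compounds shown here alone, it remains open whether this step reflects the loss of the amino group specifically or whether other small groups on the same carbon, such as methylamino, methyl or hydroxyl, would give similar numbers. It is also unclear whether the step would hold if the shared core carried a different group in place of chloromethyl, such as a plain methyl or a longer chain, as a single pair shows this change in only one setting.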